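The source may report more compounds than this note shows. Statements on the series, on what has been measured and on what is new or still open speak of the compounds shown alone.

Measured so far in a toxicity assay on THP-1 cells (Homo sapiens) for inhibition; on this read-out lower numbers stand for higher toxicity in this test and higher numbers for lower toxicity in this test:
Compound 1 `COc1ccc(-c2cnc(NC(=O)c3cnc[nH]3)n2C)cc1` gives > 100000 nM, which is a limit of the assay and not a number.
Compound 2 `COc1ccc(-c2cnc(NC(=O)c3ccccc3F)n2C)cc1` gives > 100000 nM, again a limit of the assay.
Compound 3 `COc1ccc(-c2cnc(NC(=O)c3cccc(Cl)c3)n2C)cc1` gives > 28000 nM, also only a limit of the assay.

Compound 3 thus stands at a limit, and the two further values shown are limits as well, so no ordering among the three can be read. The change to compound 4 `COc1ccc(C(=O)Nc2ncc(-c3ccc(OC)cc3)n2C)cc1` is 4-methoxyphenyl in place of 3-chlorophenyl on a carbonyl carbon. Within the data shown here, three measured steps concern the same place on the carbonyl carbon: a step that the two limits leave unreadable from compound 1 to compound 2, a step that the two limits leave unreadable from compound 1 to compound 3 and a step that the two limits leave unreadable from compound 2 to compound 3. None has a readable size because of the limit of > 100000 nM in this assay, at which 2 of the 3 values shown sit, and (the limit of > 28000 nM in this assay, at which 1 of the 3 values shown sits). Every exchange of the group on the carbonyl carbon seen so far has left the value at a limit, so the expectation for this assay is no step beyond the scatter, with compound 4 likely remaining at a limit too. Compound 4 is expected to give 100000 nM, within 30000 nM to 300000 nM. This estimate means a step that the limit leaves unreadable from compound 3 to compound 4, expected to be no change beyond the scatter.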

Compound 4, half-maximal cytotoxic concentration: > 100000 nM
Compound 4: only a limit was reported; the forecaster's own chance of this, stated with the estimate: 85%; the middle value lies on the limit itself.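

Compound 4 gives > 100000 nM in this assay, which is a limit of the assay and not a number. Its steps from compound 1, compound 2 and compound 3 therefore cannot be read. The compounds shown leave open whether the group on the carbonyl carbon affects toxicity in this test at all.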